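From phenyl to 2,4-dihydroxyphenyl in a small series

The source may report more compounds than this note shows. Statements on the series, on what has been measured and on what is new or still open speak of the compounds shown alone.

Measured in a functional assay, read by Griess assay, with a stated time of 2.5 h; a higher number here means a weaker inhibitor, a lower number a stronger inhibitor:
Compound 1 `COc1ccc(C(=O)/C=C/c2cc(OC)c(OC)cc2OC)cc1`: 2.07 ug/mL
Compound 2 `COc1cc(OC)c(OC)cc1/C=C/C(=O)c1ccccc1`: 2.01 ug/mL

Going by the values given here, the one measured step, a 1.0-fold lower number from compound 1 to compound 2 (0.01 log units; within the scatter), lies within the scatter, so compound 2 stands level with compound 1. Compound 3 `COc1cc(OC)c(OC)cc1/C=C/C(=O)c1ccc(O)cc1O` differs from compound 2 by one change: 2,4-dihydroxyphenyl in place of phenyl on a carbonyl carbon. Among the compounds with values here, the measured step, hydrogen in place of methoxy on an aromatic carbon, is the only guide, and it is a weak one, as no measured compound carries 2,4-dihydroxyphenyl. No shift beyond the scatter is therefore expected in this assay, in either direction. The expected change is a 1.0-fold lower number from compound 2 to compound 3 (0.00 log units; within the scatter). The estimate for compound 3 is 2 ug/mL, with an expected range from 0.7 ug/mL to 6 ug/mL.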

Compound 3, half-maximal inhibitory concentration: 2.76 ug/mL
The estimate for compound 3 lay 1.4-fold (0.14 log units) below the measured number, and the stated range covers the measured number.
By their numbers in this assay, from the lowest: compounds 2, 1 and 3 (each within the scatter of the next).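

In this assay, going by these compounds alone, this place on the carbonyl carbon tolerates a much larger change than the earlier compounds tested, with a 1.4-fold higher number from compound 2 to compound 3 (0.14 log units; within the scatter) and a 1.3-fold higher number from compound 1 to compound 3 (0.12 log units; within the scatter). Phenyl, 4-methoxyphenyl and 2,4-dihydroxyphenyl therefore stand level here, even though only the last carries hydrogen-bond donors. Nothing available explains why this change leaves the number within the scatter.

As far as these compounds go, whether an amine or a carboxylic acid in this place would move the number beyond the scatter remains open. So does the effect of 4-hydroxyphenyl, which would show how a lone hydroxyl behaves here.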